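A few compounds are considered here, and "the series" means these few. Any claim that something is new, unique, unknown or untested is made for them only; others in the source may bear on it.

Measured compounds:
compound 1 `O=C(c1ccc(Cl)c(C(F)(F)F)c1)N1CCC(n2cncc2-c2ccc(OS(=O)(=O)c3cccc4cnccc34)cc2)CC1` gives 22 nM
compound 2 `CN(C)c1ccc(C(=O)N2CCC(n3cncc3-c3ccc(OS(=O)(=O)c4cccc5cnccc45)cc3)CC2)cc1` gives 2.19 nM

Within the data shown here, compound 2 holds the lowest number of the two in an assay on THP-1 cells for antagonist activity at P2X purinoceptor 7 (Homo sapiens), read by ELISA, with a stated time of 30 min; on this read-out higher numbers stand for weaker inhibition and lower numbers for stronger inhibition; the single measured step, a 10-fold lower number from compound 1 to compound 2 (1.00 log units; beyond the scatter), concerns the aryl on the carbonyl carbon only. Compound 3 `CN(C)c1ccc(C(=O)N2CCC(n3cncc3-c3ccc(OS(=O)(=O)c4cccc(C(=O)NC5CC5)c4)cc3)CC2)cc1` differs from compound 2 in another place: 3-(cyclopropylcarbamoyl)phenyl in place of isoquinolin-5-yl on a sulfonyl sulfur. Among the measured compounds shown here, no measured step touches the aryl on the sulfonyl sulfur, so nothing measured bears on this change, and no step beyond the scatter is assumed. Compound 3 is therefore expected to give about 4 nM in this assay, within 1 nM to 20 nM. The step of a 1.8-fold higher number from compound 2 to compound 3 (0.26 log units; within the scatter) is expected to stay within the scatter.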

Compound 3, half-maximal inhibitory concentration: 1.03 nM
Compound 3: the middle estimate sits 3.9-fold (0.59 log units) above what was measured, within the range that was stated.
By their numbers in this assay, from the lowest: compound 3; then compound 2; then compound 1.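

In this assay the aryl on the sulfonyl sulfur proves open to exchange: 3-(cyclopropylcarbamoyl)phenyl in place of isoquinolin-5-yl gives a 2.1-fold lower number from compound 2 to compound 3 (0.33 log units; beyond the scatter), so with 4-(dimethylamino)phenyl on the carbonyl carbon, activity does not require isoquinolin-5-yl. The entering group has 1 hydrogen-bond donor where the leaving group has 0, but no available evidence explains the step.

On these data alone, it remains open which part of the entering group matters, as a carboxylic acid or a methyl amide in place of the cyclopropylcarbamoyl group would show. Whether the step carries over with 4-chloro-3-(trifluoromethyl)phenyl on the carbonyl carbon is also unresolved.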